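The source may hold more compounds than are shown below. What is called first, only, known or untested is meant among the compounds shown, and "the series" means these compounds.

Of the compounds shown here, two have numbers so far in an ADME assay on microsomes from liver (Homo sapiens) for metabolic stability, read by LC-MS, using NADPH, with a stated time of 10 min, tested at 0.1 uM; a higher number here means faster removal of the compound, a lower number slower removal. Compound 1 `C#Cc1cc(C(=O)NCCCCc2ccccc2)cc(C2SCC(=O)N2c2ccccc2OC)c1` gives 1730 mL.min-1.g-1, and compound 2 `Cc1cccc(N2C(=O)CSC2c2cccc(C(=O)NCCCCc3ccccc3)c2)c1` gives 2550 mL.min-1.g-1. These two values lie within the usual scatter of each other, so compound 2 stands level with compound 1. Compound 3 `O=C(NCCCCc1ccccc1)c1cccc(C2SCC(=O)N2c2ccccn2)c1` has pyridin-2-yl in place of 3-methylphenyl on an amide-type nitrogen in a ring, and the rest of compound 2 stays the same: pyridin-2-yl in place of 3-methylphenyl on an amide-type nitrogen in a ring. For the measured compounds named here, no two measured compounds differ in just one place, so the data offer no direct guide to this change, and any forecast must stay loose. A modest fall in this assay is expected, not clearly beyond the scatter. The estimated change is a 1.8-fold lower number from compound 2 to compound 3 (0.26 log units; within the scatter). Compound 3 is expected at 1400 mL.min-1.g-1, with an estimated range from 600 mL.min-1.g-1 to 2800 mL.min-1.g-1.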

Compound 3, intrinsic clearance in microsomes: 412 mL.min-1.g-1
For compound 3 the middle estimate is 3.4-fold (0.53 log units) above the measured one; measured number outside the range, below it.
By their numbers in this assay, from the lowest: compound 3; then compounds 1 and 2 (each within the scatter of the next).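

For the compounds shown here, this is the first step that changes one place only, and it gives a 6.2-fold lower number from compound 2 to compound 3 (0.79 log units; beyond the scatter) in this assay. It shows that the group on the amide-type nitrogen in the ring can move this number beyond the scatter while the rest of the molecule stays the same. Nothing given here explains why the number falls with pyridin-2-yl.

This one step swaps a ring carbon for a ring nitrogen and also removes the methyl group, so it cannot show which of the two changes matters, and a plain phenyl or a pyridin-3-yl at this place would help to separate them. Going by these compounds, it also remains open whether pyridin-2-yl would give a similar step with a shorter chain on the amide.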